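The source may hold more compounds than are shown below. What is called first, only, known or untested is meant among the compounds shown, and "the series" means these compounds.

Compound 1 `COc1ccccc1C(=O)n1c(-c2cn(C)c3ccccc23)nc2ccccc21`: 31800 nM
Compound 2 `COc1cccc(C(=O)n2c(-c3cn(C)c4ccccc34)nc3ccccc32)c1`: 13600 nM
Compound 3 `COc1ccc(C(=O)n2c(-c3cn(C)c4ccccc34)nc3ccccc32)cc1OC`: 8400 nM

In a functional assay on HepG2 cells (Homo sapiens) for inhibition, read by MTT assay, with a stated time of 24 h (on this read-out higher numbers stand for weaker inhibition of growth and lower numbers for stronger inhibition of growth), compound 3 and compound 2 share the low end of the three numbers, and a 3.8-fold lower number from compound 1 to compound 3 (0.58 log units; beyond the scatter) is the widest gap. Compound 4 `COc1cc(C(=O)n2c(-c3cn(C)c4ccccc34)nc3ccccc32)cc(OC)c1OC` follows from compound 3 through (methoxy in place of hydrogen on an aromatic carbon), methoxy in place of hydrogen on an aromatic carbon. The same kind of change has been measured once, a 1.6-fold lower number from compound 2 to compound 3 (0.21 log units; within the scatter), and that step stays within the scatter. The wider a 2.3-fold lower number from compound 1 to compound 2 (0.37 log units; beyond the scatter) moves a methoxy instead, so it bears less directly. A small move towards a lower number is therefore expected, possibly none beyond the scatter, with a 1.5-fold lower number from compound 3 to compound 4 (0.18 log units; within the scatter) as the expected step. For compound 4 the estimated value is 5500 nM, with an expected range of 1800 nM to 13000 nM.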

Compound 4, concentration for 50% growth inhibition: 4300 nM
The estimate for compound 4 lay 1.3-fold (0.11 log units) above the measured number; the measured number falls inside the stated range.
By their numbers in this assay, from the lowest: compounds 4, 3 and 2 (each within the scatter of the next, the first and the last beyond it); then compound 1.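

In this assay, methoxy in place of hydrogen on this aromatic carbon, ortho to a methoxy group and meta to a large group, gives a 2.0-fold lower number from compound 3 to compound 4 (0.29 log units; within the scatter). The same kind of change at the earlier position gave a 1.6-fold lower number from compound 2 to compound 3 (0.21 log units; within the scatter), so neither single methoxy addition on this ring separates from the scatter. No evidence on the origin of this result is available.

From the compounds shown here alone, whether a hydroxyl or an amine at this position would give a step beyond the scatter remains open. Larger alkoxy groups, such as ethoxy, also remain open.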